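Replacing Ethoxy with Dimethylamino in Compound 2

The compounds below may be only part of what the source reports. "The series", "measured", "known", "first", "only" and "open" are said of these compounds alone.

In a functional assay for inhibition, with Homo sapiens as the target (a lower number here means a stronger inhibitor, a higher number a weaker inhibitor), compound 1 (`COc1cccc(/C=C/C(=O)c2c(OC)cc(OC)cc2OC)c1`) gives 1800 nM, while compound 2 (`CCOc1ccccc1C(=O)/C=C/c1ccccc1`) gives 609 nM. That is the lower of the two numbers, marking the stronger inhibitor, and the gap lies beyond the usual scatter. Compound 3 (`CN(C)c1ccccc1C(=O)/C=C/c1ccccc1`) differs from compound 2 in one place, with dimethylamino in place of ethoxy on an aromatic carbon. Among the compounds with values here, no measured pair shows this swap. Only a small rise, within the scatter, is expected in this assay. The estimated step is a 1.3-fold higher number from compound 2 to compound 3 (0.12 log units; within the scatter). Compound 3 is expected at 800 nM, with a range of 250 nM to 2600 nM.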

Compound 3, half-maximal inhibitory concentration: 1770 nM
Beside the measured number, compound 3's estimate is 2.2-fold (0.34 log units) below it; the measured number falls inside the stated range.
By their numbers in this assay, from the lowest: compound 2; then compounds 3 and 1 (each within the scatter of the next).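

Within the data shown here, this is the first direct reading of this position: in this assay, dimethylamino in place of ethoxy, on an aromatic carbon ortho to a large group, gives a 2.9-fold higher number from compound 2 to compound 3 (0.46 log units; beyond the scatter) and so weakens inhibition. The two groups have the same counts of heavy atoms, hydrogen-bond donors and acceptors, and neither carries a net charge, yet the position still distinguishes between them. Nothing available explains this difference.

On these data alone, whether a primary amine or a longer chain such as propoxy would match or improve on ethoxy here remains open. So does whether this swap would have the same effect on a different core.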